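This account rests on a few compounds, and the source may have more. Where it says the series, first, only, none or still open, it means among the compounds named here.

Measured compounds:
compound 1 `C=C1C(=O)[C@]23C[C@@]1(O)CC[C@H]2c1ccc(OS(=O)(=O)c2ccc(C)cc2)c(C)c1[C@@H]3Cn1cc(-c2ccc(Cl)cc2)nn1`: 1440 nM
compound 2 `C=C1C(=O)[C@]23C[C@@]1(O)CC[C@H]2c1ccc(OS(=O)(=O)c2ccc(C)cc2)c(C)c1[C@@H]3Cn1cc(-c2ccc(F)cc2)nn1`: 330 nM

Notes on the series. In a functional assay on MCF7 cells (Homo sapiens) for cytotoxicity, read by MTT assay, with a stated time of 4 days (a lower number here means a stronger inhibitor, a higher number a weaker inhibitor), compound 2 gives the lower of the two numbers recorded so far; the nearest measured point is compound 1, and the step of a 4.4-fold lower number from compound 1 to compound 2 (0.64 log units; beyond the scatter) is beyond the scatter, so the difference between compounds 1 and 2 is a real one. Both carry the same shared core; they differ only in the group on the six-membered aromatic ring of carbon only.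

Compound 3 `C=C1C(=O)[C@]23C[C@@]1(O)CC[C@H]2c1ccc(OS(=O)(=O)c2ccc(C)cc2)c(C)c1[C@@H]3Cn1cc(-c2ccc(OC)cc2)nn1` differs from compound 2 by methoxy in place of fluoro on an aromatic carbon, so the change sits on the same aromatic carbon that carried chloro in compound 1 and fluoro in compound 2. Going by the values given here, no measured step covers methoxy at this place. Among the compounds with values here, the one step that bears on it, a 4.4-fold lower number from compound 1 to compound 2 (0.64 log units; beyond the scatter), shows that a swap of the group on this carbon can shift this assay by a modest but real amount, in either direction as far as can be told from two points. Within the data shown here, with no direct precedent, compound 3 is expected to give a number that need not differ beyond the scatter from compound 2, with a wide range to cover the uncertainty: the expected step is a 1.8-fold higher number from compound 2 to compound 3 (0.26 log units; within the scatter). The estimate for compound 3 in this assay is 600 nM, within 200 nM to 2000 nM.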

Compound 3, half-maximal inhibitory concentration: 310 nM
The estimate for compound 3 lay 1.9-fold (0.29 log units) above the measured number; the measured number falls inside the stated range.
By their numbers in this assay, from the lowest: compounds 3 and 2 (each within the scatter of the next); then compound 1.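

In this assay, a 1.1-fold lower number from compound 2 to compound 3 (0.03 log units; within the scatter), so on this aromatic carbon, para to a large group, methoxy and fluoro cannot be told apart, even though methoxy carries 2 heavy atoms and 1 hydrogen-bond acceptor against the 1 heavy atom and 0 hydrogen-bond acceptors of fluoro. Measured against chloro, methoxy gives a 4.6-fold lower number from compound 1 to compound 3 (0.67 log units; beyond the scatter), a step beyond the scatter that matches fluoro in direction, so the difference at this position now separates chloro from two unlike groups rather than from a single replacement, and compound 1 stands apart from compound 2 and compound 3. Nothing measured accounts for why chloro differs from the other two groups.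

On these data alone, it remains open whether this level holds for groups further from these three, such as an amine or a carboxylic acid on the same carbon, or a longer chain such as butoxy in place of methoxy. The plain phenyl, with hydrogen on this carbon, would show whether fluoro and methoxy lower the number or chloro raises it.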